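The compounds below may be only part of what the source reports. "The series", "measured", "known", "first", "only" and "open" are said of these compounds alone.

Three compounds share one core here: compound 1 `Cc1cc(NC(=O)Nc2cccc([N+](=O)[O-])c2)c2ccccc2n1` and compound 2 `Cc1cc(NC(=O)Nc2ccc(F)cc2)c2ccccc2n1` have been measured, while compound 3 `Cc1cc(NC(=O)Nc2cccc(F)c2)c2ccccc2n1` has not. In an ADME assay on BJ cells (Homo sapiens) for cytotoxicity, with a stated time of 72 h (on this read-out lower numbers stand for an effect already at smaller amounts and higher numbers for an effect only at larger amounts of compound), compound 1 gives > 25000 nM as a limit of the assay and not a number. In this assay compound 2 gives > 25000 nM as a limit too, so it has no exact value. Among the measured compounds shown here, the two measured compounds together show the limit of > 25000 nM in this assay, at which 2 of the 2 values shown sit, and offer no measured step. Compound 3 differs from compound 2 in one place, with 3-fluorophenyl in place of 4-fluorophenyl on an amide-type nitrogen. With compound 2 at > 25000 nM as a limit, no change beyond the scatter is expected in this assay and neither direction is favoured. The expected change is a step that the limit leaves unreadable from compound 2 to compound 3 by this estimate. For compound 3 the estimated value is 30000 nM with an expected range of 15000 nM to 60000 nM in this estimate.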

Compound 3, half-maximal effective concentration: > 25000 nM
Compound 3: a limit, no number; the forecaster's own chance of this, stated with the estimate: 85%; the middle value lies beyond the limit too.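

In this assay compound 3 gives > 25000 nM, a limit and not a number. Among the compounds shown here, no step from compound 1 or compound 2 to compound 3 can be read. The compounds shown leave open whether any of them has an effect at larger amounts, and whether their differing groups change anything in this assay.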